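The source may report more compounds than this note shows. Statements on the series, on what has been measured and on what is new or still open speak of the compounds shown alone.

In a functional assay on HepG2 cells (Homo sapiens) for antiproliferative activity, read by CCK-8 assay, with a stated time of 72 h, tested at 8 uM (on this read-out higher numbers stand for a stronger effect at the one concentration tested and lower numbers for a weaker effect), three compounds have been measured so far. Compound 1 `Nc1ccccc1NC(=O)/C=C/c1ccc(Cn2cnc3c(Nc4cccc(Cl)c4)nc(Cl)nc32)cc1` gives 49.3% and compound 2 `Nc1ccccc1NC(=O)c1ccc(Cn2cnc3c(Nc4ccc(-c5ccccn5)cc4)nc(Cl)nc32)cc1` gives 41.2%, while compound 3 `Nc1ccccc1NC(=O)c1ccc(CNc2nc(Cl)nc3c2ncn3Cc2ccccc2)cc1` gives 5.32%, the lowest of the three numbers and beyond the scatter from both of the others. Compound 4 `CCCn1cnc2c(NCc3ccc(C(=O)Nc4ccccc4N)cc3)nc(Cl)nc21` has not yet been measured in this assay. It differs from compound 3 in one place: ethyl in place of phenyl on a saturated chain carbon bound to an aromatic nitrogen. Going by the values given here, no measured pair shows this change, so the data give nothing that fixes its effect. Because compound 3 gives 5.32%, near the bottom of the scale, the change is expected to shift the number only a little, if at all beyond the scatter. The expected step is a number 2.7 percentage points higher from compound 3 to compound 4 (within the scatter). Compound 4 is therefore estimated at 8%, with a range from 0% to 25%.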

Compound 4, a percentage reported as inhibition, at one concentration (the size of the read-out at that concentration, not a potency): 14.1%
Estimate against measurement, compound 4: 6.1 percentage points below, and the stated range covers the measured number.
By their numbers in this assay, from the lowest: compounds 3 and 4 (each within the scatter of the next); then compounds 2 and 1 (each within the scatter of the next).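

In this assay, going by these compounds alone, swapping phenyl for ethyl on a saturated chain carbon bound to an aromatic nitrogen gives a number 8.8 percentage points higher from compound 3 to compound 4 (within the scatter), the first reading of this position. The aromatic ring at this place can thus be given up for a short open chain, benzyl to propyl, without a change beyond the scatter. No evidence at hand accounts for this result. On these data alone, whether a longer chain, an amine or a carboxylic acid at this place would move the number remains open. So does whether the same swap would read alike on the cores of the other compounds.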